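Amide tail swap on the shared core

The source may hold more compounds than are shown below. What is called first, only, known or untested is meant among the compounds shown, and "the series" means these compounds.

In an assay on isolated protein for inhibition of thyroid hormone receptor alpha (Homo sapiens), read by fluorescence polarization (on this read-out higher numbers stand for weaker inhibition and lower numbers for stronger inhibition), compound 1 `CN(Cc1ccccc1F)C(=O)C1CCN(C(=O)c2ccc(S(C)(=O)=O)c([N+](=O)[O-])c2)CC1` gives only a limit of > 60000 nM and no number. Compound 2 `CS(=O)(=O)c1ccc(C(=O)NCC(=O)N2CCN(c3ccccc3F)CC2)cc1[N+](=O)[O-]` likewise gives only a limit of > 60000 nM in this assay. Compound 3 `CN1CCN(C(=O)CNC(=O)c2ccc(S(C)(=O)=O)c([N+](=O)[O-])c2)CC1` also returns only a limit of > 60000 nM. Among the compounds with values here, the single step between measured compounds, a step that the two limits leave unreadable from compound 2 to compound 3, is therefore unreadable, since all three values sit at the limit of > 60000 nM in this assay, at which 3 of the 3 values shown sit. Compound 4 `CS(=O)(=O)c1ccc(C(=O)N2CCC(C(=O)N3CCc4ccccc4C3)CC2)cc1[N+](=O)[O-]` differs from compound 1 by 1,2,3,4-tetrahydroisoquinolin-2-yl in place of (2-fluorobenzyl)(methyl)amino on a carbonyl carbon. Within the data shown here, no measured step bears on this change, and compound 1 itself stands only at a limit, so no size or direction can be expected beyond the scatter. The step from compound 1 to compound 4 is expected as a step that the limit leaves unreadable from compound 1 to compound 4. Compound 4 is expected to give 80000 nM, within 25000 nM to 250000 nM, most probably again reported as a limit.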

Compound 4, half-maximal inhibitory concentration: > 60000 nM
Compound 4: a limit, no number (the forecaster's own chance of this, stated with the estimate: 85%); the middle value lies beyond the limit too.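

No step can be read between compound 1 and compound 4: both give only a limit. The compounds shown leave open whether any amide tail on the shared core gives a measurable inhibition value, and how the tails rank: the limit of > 60000 nM in this assay, at which 4 of the 4 values shown sit.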